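The compounds below may be only part of what the source reports. "The series", "measured", "known", "first", "only" and "open" are said of these compounds alone.

In a functional assay on HCT-116 cells (Homo sapiens) for inhibition, read by MTT assay, with a stated time of 48 h (on this read-out lower numbers stand for stronger inhibition and higher numbers for weaker inhibition), three compounds have been measured so far, and none of them gives an exact number. Compound 1 `COc1ccc(-n2c(S)nnc2-c2cc(OC)c(OC)c(OC)c2)cc1` reads > 60000 nM, which is a limit of the assay. Compound 2 `CCSc1nnc(-c2cc(OC)c(OC)c(OC)c2)n1-c1ccc(OC)cc1` reads > 60000 nM, again a limit. Compound 3 `CCSc1nnc(-c2cc(OC)c(OC)c(OC)c2)n1-c1ccc(N(C)C)cc1` reads > 60000 nM, also a limit. Compound 3 therefore has no exact position, and the whole set is summed up by the limit of > 60000 nM in this assay, at which 3 of the 3 values shown sit.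

Compound 4 `COc1cc(-c2nnc(SCC(=O)c3ccc(F)cc3)n2-c2ccc(N(C)C)cc2)cc(OC)c1OC` differs from compound 3 in the group on the sulfur: (4-fluorophenyl)carbonyl in place of methyl on a saturated chain carbon bound to a sulfur. Put simply, ethyl becomes ((4-fluorophenyl)carbonyl)methyl, which adds one six-membered aromatic ring of carbon only.

Two measured steps offer some guidance, though neither has a readable size. The closer one, made on the same sulfur, is a step that the two limits leave unreadable from compound 1 to compound 2. The other, made elsewhere on the molecule, is a step that the two limits leave unreadable from compound 2 to compound 3. Neither step moved a reading off the limit, so they support no large gain, although a modest shift toward stronger inhibition in this assay remains possible. The expected change is an at least 2.0-fold lower number from compound 3 to compound 4 (0.30 log units; that floor lies within the scatter). For compound 4 the estimate is 30000 nM, with an expected range of 6000 nM to 60000 nM.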

Compound 4, half-maximal inhibitory concentration: 31100 nM
Estimate against measurement, compound 4: 1.0-fold (0.02 log units) below, and the stated range covers the measured number.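

In this assay, the change on the saturated chain carbon bound to a sulfur gives an at least 1.9-fold lower number from compound 3 to compound 4 (0.28 log units; that floor lies within the scatter). Among these compounds, this is the first step in the set with a readable size, as the earlier steps cannot be read, although the figure is only a floor and the true gap could be larger. Compound 4 is also the only compound here with an exact number, so ((4-fluorophenyl)carbonyl)methyl is the one group on the sulfur so far that brings a reading off the limit, while the rest of the set stays there: the limit of > 60000 nM in this assay, at which 3 of the 4 values shown sit.

From the compounds shown here alone, it remains open whether the carbonyl, the 4-fluorophenyl ring or simply the larger group accounts for this exact reading, and whether the same group would give an exact reading with methoxy in place of dimethylamino. Going by these compounds, how a carboxylic acid, an amine or a longer alkyl chain on the sulfur would read in this assay is also open, as is whether any group at this position can bring the number far below that of compound 4.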